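This account rests on a few compounds, and the source may have more. Where it says the series, first, only, none or still open, it means among the compounds named here.

Compound 1, `O=[N+]([O-])c1ccccc1-c1ncco1`: 1.27
Compound 2, `FC(F)(F)c1ccccc1C1=NC(c2ccccc2)CO1`: 3.71
Compound 3, `Clc1ccc(C2=NC(c3ccccc3)CO2)cc1`: 4.48

All three numbers come from a physicochemical assay for lipophilicity; on this read-out lower numbers stand for lower lipophilicity and higher numbers for higher lipophilicity. Among them compound 1 stands lowest. Compound 2 is its nearest neighbour, and even that value lies higher by a margin beyond the scatter; compound 3 is furthest away, higher still, again well beyond the scatter. Among the measured compounds shown here, none of the three measured compounds differ from one another in a single place, so no step can be read off directly between them, and the two higher values say only that those two compounds sit far above compound 1 in this assay.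

Compound 4, `Ic1ccccc1-c1ncco1`, has not yet been measured. It differs from compound 1 in one place: iodo in place of nitro on an aromatic carbon. The nitro that leaves carries two hydrogen-bond acceptors; the iodo that enters carries none, and it sits on the same aromatic carbon, ortho to a group of 5 heavy atoms.

For this change a clear step upward in this assay is expected, beyond the scatter, though well short of the distance to compound 2 or compound 3. Compound 4 is therefore expected to give about 2.7, with a likely range from 2.3 to 3.1. That expectation amounts to a step of a number 1.43 log units higher from compound 1 to compound 4 (beyond the scatter).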

Compound 4, partition coefficient: 2.3
Compound 4: the middle estimate sits 0.40 log units above what was measured; low and high end bracket the measured number.
By their numbers in this assay, from the lowest: compound 1; then compound 4; then compound 2; then compound 3.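

Among the compounds shown here, for the first time, a single change can be read directly: iodo in place of nitro on an aromatic carbon, ortho to a group of 5 heavy atoms, gives a number 1.03 log units higher from compound 1 to compound 4 (beyond the scatter) in this assay with the rest of the structure unchanged. The earlier compounds shown here differ in more than one place, so their gaps could not be tied to any one group, whereas here the whole difference lies at this single position. The nitro that leaves has 2 hydrogen-bond acceptors and the iodo that enters has none, but nothing measured here shows what lies behind the step, so that count remains a description only.

From the compounds shown here alone, this is one pair at one position, so it remains open whether the same exchange would give a step of similar size on a different core or at another place on the aromatic ring. Going by these compounds, it also remains open where other groups on this aromatic carbon would fall in comparison with nitro and iodo, such as an amine, a carboxylic acid or a methoxy group.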